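Side-chain swaps on the shared core: compound 3

This account rests on a few compounds, and the source may have more. Where it says the series, first, only, none or still open, it means among the compounds named here.

Measured so far:
compound 1, `N=C(N)NCCC[C@H](NC(=O)CN(c1nc(Cl)nc2[nH]cnc12)C1CC1)C(=O)OCc1ccccc1`, 6.12%
compound 2, `NCCCC[C@H](NC(=O)CN(c1nc(Cl)nc2[nH]cnc12)C1CC1)C(=O)OCc1ccccc1`, 9.88%

Among the measured compounds shown here, in a functional assay on the whole organism (Tail, strain ICR) with Mus musculus as the target, in the tail flick test, with a stated time of 150 min, at a dose of 25 umol/kg by the oral route (on this read-out higher numbers stand for a stronger effect at the one dose given and lower numbers for a weaker effect), compound 2 gives 9.88%, standing within the scatter of compound 1, the only other number, as the step of a number 3.8 percentage points higher from compound 1 to compound 2 (within the scatter) shows. Compound 3, `CC[C@H](C)[C@H](NC(=O)CN(c1nc(Cl)nc2[nH]cnc12)C1CC1)C(=O)OCc1ccccc1`, differs from compound 2 by sec-butyl in place of 4-aminobutyl on a saturated chain carbon bound to an amide-type nitrogen and a carbonyl carbon. For the measured compounds named here, no measured step bears on this change; the single step on record is within the scatter, so nothing beyond the scatter is expected, and the step of a number 1.9 percentage points lower from compound 2 to compound 3 (within the scatter) is the estimate. Compound 3 is therefore expected at 8%, estimated between 0% and 20%.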

Compound 3, a percentage reported as activity, at one dose (the size of the read-out at that dose, not a potency): 6.9%
Beside the measured number, compound 3's estimate is 1.1 percentage points above it; measured number inside the range.
By their numbers in this assay, from the lowest: compounds 1, 3 and 2 (each within the scatter of the next).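

At this chain carbon, in this assay, sec-butyl in place of 4-aminobutyl gives a number 3 percentage points lower from compound 2 to compound 3 (within the scatter), and the all-carbon group against the larger nitrogen-bearing group gives a number 0.8 percentage points higher from compound 1 to compound 3 (within the scatter). A side chain of carbon alone thus reads within the scatter of both nitrogen-bearing chains, so the three compounds do not separate at this position. No measurement at hand accounts for these numbers. Open, going by these compounds, is whether a carboxylic acid or a phenyl ring on this chain carbon would move the number beyond the scatter. Also open, on these data alone, is whether another dose or time would separate these three side chains.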